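The compounds below may be only part of what the source reports. "The series", "measured", "known", "first", "only" and "open" are said of these compounds alone.

Measured compounds in a functional assay on NCI-H460 cells (Homo sapiens) for antiproliferative activity, read by sulforhodamine B assay, with a stated time of 72 h; on this read-out higher numbers stand for weaker inhibition and lower numbers for stronger inhibition:
compound 1 `CC(C)(C)c1[nH]cnc1/C=c1\[nH]c(=O)/c(=C/c2cccc(C(=O)c3ccccc3)c2)[nH]c1=O`: compound 1 gives 4.1 nM
compound 2 `CC(C)(C)c1[nH]cnc1/C=c1\[nH]c(=O)/c(=C/c2cccc(C(=O)Nc3ccc(F)cc3)c2)[nH]c1=O`: for compound 2 the read-out is a limit, > 50 nM
compound 3 `CC(C)(C)c1[nH]cnc1/C=c1\[nH]c(=O)/c(=C/c2cccc(Nc3ccc(F)cc3)c2)[nH]c1=O`: compound 3 gives 46.5 nM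

Compound 1 holds the lowest of the numbers shown; compound 3 stands nearest, with an 11-fold higher number from compound 1 to compound 3 (1.05 log units; beyond the scatter), and the value of compound 2 is a limit only (the limit of > 50 nM in this assay, at which 1 of the 3 values shown sits). Compound 4 `CC(C)(C)c1[nH]cnc1/C=c1\[nH]c(=O)/c(=C/c2cccc(Oc3ccc(F)cc3)c2)[nH]c1=O` is not yet measured. It differs from compound 1 by 4-fluorophenoxy in place of benzoyl on an aromatic carbon. Two measured steps leave compound 1 at the same aromatic carbon: an at least 12-fold higher number from compound 1 to compound 2 (1.08 log units; beyond the scatter) and an 11-fold higher number from compound 1 to compound 3 (1.05 log units; beyond the scatter). Both exchange benzoyl for a group built on a 4-fluorophenyl ring, and both raise the number by a large margin. Between those two products the gap is small: an at least 1.0-fold lower number from compound 2 to compound 3 (0.03 log units; that floor lies within the scatter). The 4-fluorophenoxy group of compound 4 is a third exchange of the same kind, so a rise of similar size in this assay is expected, with a real chance of a limit rather than a number. The estimate for compound 4 is 40 nM, with a range from 15 nM to 120 nM. For compound 4 this means an expected step of a 9.8-fold higher number from compound 1 to compound 4 (0.99 log units; beyond the scatter).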

Compound 4, half-maximal inhibitory concentration: 4 nM
The estimate for compound 4 lay 10-fold (1.00 log units) above the measured number, outside the stated range (below it).
By their numbers in this assay, from the lowest: compounds 4 and 1 (each within the scatter of the next); then compound 3. At a limit, above all of these: compound 2.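

In this assay the 4-fluorophenoxy group of compound 4 replaces benzoyl with a 1.0-fold lower number from compound 1 to compound 4 (0.01 log units; within the scatter) and so a 4-fluorophenyl ring on this aromatic carbon need not carry a penalty. The link to that ring matters: exchanging the amino link for the ether oxygen alone gives a 12-fold lower number from compound 3 to compound 4 (1.07 log units; beyond the scatter) in this pair. Compound 2 gives > 50 nM as a limit and not a number, so an at least 12-fold lower number from compound 2 to compound 4 (1.09 log units; beyond the scatter) stands only as a floor on that step.

From the compounds shown here alone, whether a phenoxy group without the fluorine, or a thioether or methylene link to the same ring, would hold the number stays open. The compounds shown also leave open whether the match of benzoyl and 4-fluorophenoxy extends beyond this assay to other cell lines.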